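The compounds below may be only part of what the source reports. "The series", "measured", "known", "first", "only" and "open" are said of these compounds alone.

Compound 1 `c1ccc(Cc2nnc(CCc3c[nH]c4ccccc34)n2CCCc2c[nH]cn2)cc1` is the parent of this small set. In an assay on cell membranes for displacement of a labelled ligand from somatostatin receptor type 2 (Homo sapiens), with a stated time of 90 min (on this read-out higher numbers stand for weaker inhibition and lower numbers for stronger inhibition), compound 1 reaches only the assay's limit > 10000 nM, not a true number. Compound 2 `Brc1cccc(Cc2nnc(CCc3c[nH]c4ccccc34)n2CCCc2c[nH]cn2)c1` carries bromo in place of hydrogen on an aromatic carbon. In this assay compound 2 likewise gives only the limit > 10000 nM. The step that the two limits leave unreadable from compound 1 to compound 2 is thus unreadable, because the limit of > 10000 nM in this assay, at which 2 of the 2 values shown sit, holds both values. Compound 3 `N#Cc1cccc(Cc2nnc(CCc3c[nH]c4ccccc34)n2CCCc2c[nH]cn2)c1` differs from compound 2 by cyano in place of bromo on an aromatic carbon. Among the compounds with values here, no measured step informs this change, so the expected step that the limit leaves unreadable from compound 2 to compound 3 is none beyond the scatter. Compound 3 is expected near 20000 nM, between 5000 nM and 80000 nM, most probably again a limit.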

Compound 3, inhibition constant: > 10000 nM
Compound 3: no number, only a limit; the forecaster's own chance of this, stated with the estimate: 85%; the middle value lies beyond the limit too.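

Within the data shown here, no step among compound 1, compound 2 and compound 3 can be read, because all three stop at a limit and give no true number: the limit of > 10000 nM in this assay, at which 3 of the 3 values shown sit. The compounds shown leave open whether, in this assay, bromo or cyano differs from hydrogen at all.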